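Swapping one ethylpyridine for another at the assay limit

The compounds below may be only part of what the source reports. "The series", "measured", "known", "first", "only" and "open" are said of these compounds alone.

Compound 1 `O=C(O)c1ccc(COCc2cccc3nc(C(=O)NCc4ccccc4)[nH]c(=O)c23)cc1` gives > 20000 nM
Compound 2 `O=C(O)c1ccc(COCc2cccc3nc(C(=O)NCc4cccc(C(F)(F)F)c4)[nH]c(=O)c23)cc1` gives > 20000 nM
Compound 3 `CCc1ccnc(CNC(=O)c2nc3cccc(COCc4ccc(C(=O)O)cc4)c3c(=O)[nH]2)c1` gives > 20000 nM

In an ADME assay on HEK293 cells (Homo sapiens) for cytotoxicity, read by resazurin assay, with a stated time of 72 h (a lower number here means that less compound is tolerated, a higher number that more compound is tolerated), compound 3 stands at > 20000 nM as a limit of the assay and not a number. Each of the three entries above is such a limit, so the whole picture so far is the limit of > 20000 nM in this assay, at which 3 of the 3 values shown sit, and nothing more. Compound 4 `CCc1cncc(CNC(=O)c2nc3cccc(COCc4ccc(C(=O)O)cc4)c3c(=O)[nH]2)c1` has the same atoms as compound 3, joined differently 5-ethylpyridin-3-yl in place of 4-ethylpyridin-2-yl on a saturated chain carbon bound to an amide-type nitrogen with 5-ethylpyridin-3-yl in place of 4-ethylpyridin-2-yl on a saturated chain carbon bound to an amide-type nitrogen. The nearest measured changes a step that the two limits leave unreadable from compound 1 to compound 3 and a step that the two limits leave unreadable from compound 2 to compound 3 and also a step that the two limits leave unreadable from compound 1 to compound 2 give no size, so no step beyond the usual scatter is expected in this assay in either direction. The expected outcome is a number no higher from compound 3 to compound 4 (the limit leaves the size open) as an estimate only. Compound 4 is expected at 20000 nM with an estimated range from 12000 nM to 40000 nM and will probably be reported as a limit again.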

Compound 4, half-maximal cytotoxic concentration: > 20000 nM
Compound 4 was reported as a limit; the forecaster's own chance of this, stated with the estimate: 90%; the middle value sits exactly at the limit.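

Compound 4 joins compound 1, compound 2 and compound 3 at the assay limit, so no step to compound 4 can be read: the limit of > 20000 nM in this assay, at which 4 of the 4 values shown sit.

The compounds shown leave open whether 4-ethylpyridin-2-yl and 5-ethylpyridin-3-yl differ at all in this read-out.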